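Imidazole to dimethylamine on the butyl chain of compound 1

A few compounds are considered here, and "the series" means these few. Any claim that something is new, unique, unknown or untested is made for them only; others in the source may bear on it.

Measured compounds and values:
- compound 1, `O=C1c2c[n+]([O-])c3ccccc3c2C(=O)c2c1c1ccccc1n2CCCCn1ccnc1`: 280 nM
- compound 2, `CC1(C)OCC(Cn2cc(Cn3c4c(c5ccccc53)C(=O)c3c[n+]([O-])c5ccccc5c3C4=O)nn2)O1`: 5510 nM
- compound 3, `O=C1c2c[n+]([O-])c3ccccc3c2C(=O)c2c1c1ccccc1n2Cc1cn([C@H]2C[C@H](O)[C@@H](CO)O2)nn1`: 3600 nM

In a toxicity assay on HEK-293T cells (Homo sapiens) for cytotoxicity, read by MTT assay, with a stated time of 72 h (a higher number here means a weaker inhibitor, a lower number a stronger inhibitor), compound 1 gives the lowest number of the three, with compound 3 nearest and compound 2 furthest, both separated from compound 1 by more than the scatter. Compound 4, `CN(C)CCCCn1c2c(c3ccccc31)C(=O)c1c[n+]([O-])c3ccccc3c1C2=O`, differs from compound 1 by dimethylamino in place of 1H-imidazol-1-yl on a saturated chain carbon, four bonds along the chain from an aromatic nitrogen. For the measured compounds named here, the one step among the measured compounds, a 1.5-fold lower number from compound 2 to compound 3 (0.18 log units; within the scatter), concerns the group carried on the triazole ring and lies within the scatter; it does not touch the chain end and so has no bearing on the change from compound 1 to compound 4. Going by the values given here, no measured pair separates an imidazol-1-yl from a dimethylamino group on a saturated chain. For compound 4 the expectation is therefore a number close to that of compound 1, with no step beyond the scatter, estimated as a 1.1-fold higher number from compound 1 to compound 4 (0.03 log units; within the scatter) in this assay. Compound 4 is expected to give about 300 nM, within the range 100 nM to 900 nM.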

Compound 4, half-maximal inhibitory concentration: 520 nM
Compound 4: the middle estimate sits 1.7-fold (0.24 log units) below what was measured; the measured number falls inside the stated range.
By their numbers in this assay, from the lowest: compounds 1 and 4 (each within the scatter of the next); then compounds 3 and 2 (each within the scatter of the next).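

In this assay, for the compounds shown here, a 1.9-fold higher number from compound 1 to compound 4 (0.27 log units; within the scatter) gives the first direct reading at this chain end, for dimethylamino in place of 1H-imidazol-1-yl on a saturated chain carbon, four bonds along the chain from an aromatic nitrogen. Across this pair, the five-membered aromatic ring can give way to a group with no ring without a step beyond the scatter, so the ring is not needed at this place for a number in this range. Nothing measured here explains the size of this step.

Open, from the compounds shown here alone, is whether other chain ends, such as morpholine, piperidine or a carboxylic acid, would stay within the scatter of compound 1. Also open, going by these compounds, is whether the same holds with 3-(dimethylamino)propyl or a longer chain carrying the dimethylamino group.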